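The compounds below may be only part of what the source reports. "The series", "measured", "known", "first", "only" and "open" are said of these compounds alone.

Measured so far:
- Compound 1 `COc1cc(OC)c(-c2coc3cc(OCC(=O)c4cccc(C(F)(F)F)c4)ccc3c2=O)cc1OC`: > 10000 nM (a limit of the assay)
- Compound 2 `COc1cc(OC)c(-c2coc3cc(OCc4cccc(F)c4)ccc3c2=O)cc1OC`: 3510 nM

Among the measured compounds shown here, in a functional assay on U-251 cells (Homo sapiens) for antiproliferative activity, read by MTT assay, with a stated time of 24 h (on this read-out lower numbers stand for stronger inhibition and higher numbers for weaker inhibition), compound 2 gives 3510 nM, the only true number so far. The reading for compound 1 is a limit, > 10000 nM, and not a number.

Compound 3 `COc1cc(OC)c(-c2coc3cc(OCc4ccc(Cl)cc4)ccc3c2=O)cc1OC` carries 4-chlorophenyl in place of 3-fluorophenyl on a saturated chain carbon bound to an oxygen on an aromatic ring.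

For the measured compounds named here, one measured step bears on this place: an at least 2.8-fold lower number from compound 1 to compound 2 (0.45 log units; beyond the scatter). That step removes a carbonyl-bearing group, so it gives no direct size for an exchange between two halogenated phenyl groups. No step beyond the scatter is therefore expected in this assay, and the direction is left open. The estimated change is a 1.1-fold lower number from compound 2 to compound 3 (0.04 log units; within the scatter). For compound 3 the expected value is 3200 nM, with an estimated range from 1300 nM to 8500 nM.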

Compound 3, half-maximal inhibitory concentration: 470 nM
Estimate against measurement, compound 3: 6.8-fold (0.83 log units) above, outside the stated range (below it).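

In this assay, the exchange of one halogenated phenyl group for another on a saturated chain carbon bound to an oxygen on an aromatic ring gives a 7.5-fold lower number from compound 2 to compound 3 (0.87 log units; beyond the scatter) and so is not a silent change. This position therefore responds to the phenyl group alone, with the chain carbon and the shared core unchanged, which the earlier step could not show since it also removed a carbonyl. The wider step, an at least 21-fold lower number from compound 1 to compound 3 (1.32 log units; beyond the scatter), rests on a limit for compound 1 and so gives only a bound: the limit of > 10000 nM in this assay, at which 1 of the 3 values shown sits.

The compounds shown leave open whether the kind of halogen or its place on the ring carries the step, which 3-chlorophenyl and 4-fluorophenyl groups would separate. Also open, from the compounds shown here alone, is how a plain phenyl, 4-bromophenyl or 4-methoxyphenyl group would read here.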